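Working notes: from compound 3 to compound 4

The source may report more compounds than this note shows. Statements on the series, on what has been measured and on what is new or still open speak of the compounds shown alone.

The series shares one core, varied only at the aryl group on the far ring. Compound 1 `O=c1ccc2cc(OCc3cc(-c4ccc5ccccc5c4)no3)ccc2o1` carries a naphthalene attached at one position, compound 2 `O=c1ccc2cc(OCc3cc(-c4cccc5ccccc45)no3)ccc2o1` the same naphthalene attached at another. In a functional assay on HL-60 cells (Homo sapiens) for cytotoxicity, read by MTT assay, with a stated time of 48 h (a lower number here means a stronger inhibitor, a higher number a weaker inhibitor), compound 1 gives 55700 nM. In this assay compound 2 gives 41600 nM. These two values lie within the usual scatter of each other, so nothing can be said about an order between them; both sit at the weak end of the range.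

Compound 3 `COc1cccc(-c2cc(COc3ccc4oc(=O)ccc4c3)on2)c1` bears a 3-methoxyphenyl group. In this assay, for the measured compounds named here, compound 3 gives "not determined" (no result reported), so compound 3 stands without a number of its own, and no step to it can be drawn from compound 1 or compound 2.

Compound 4 `O=c1ccc2cc(OCc3cc(-c4cccc([N+](=O)[O-])c4)no3)ccc2o1` differs from compound 3 in one place: nitro in place of methoxy on an aromatic carbon. The change sits on an aromatic carbon of a six-membered aromatic ring of carbon only. Going by the values given here, with no measured anchor for compound 3, the size and direction of the step cannot be read from the series; the only guide is that both measured compounds are weak. On that basis compound 4 is expected to fall in the same weak range, estimated at 45000 nM with a range of 15000 nM to 130000 nM.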

Compound 4, half-maximal inhibitory concentration: 44400 nM
Compound 4: middle estimate off by 1.0-fold (0.01 log units), on the high side, within the range that was stated.
By their numbers in this assay, from the lowest: compounds 2, 4 and 1 (each within the scatter of the next).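

For the compounds shown here, compound 3 has no number of its own in this assay, so no step to compound 4 can be read. Nothing at hand bears on a cause for the value of compound 4. The compounds shown leave open how the 3-methoxyphenyl and 3-nitrophenyl groups compare in this assay.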